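The compounds below may be only part of what the source reports. "The series", "measured", "known", "first", "only" and "open" are said of these compounds alone.

Measured so far:
Compound 1 `Fc1ccc(-c2cn3ccnc3c(-c3ccc4ncn(C5CCCCC5)c4c3)n2)cc1`: 20.3%
Compound 2 `Clc1ccc(-c2cn3ccnc3c(-c3ccc4ncn(C5CCCCC5)c4c3)n2)cc1`: 23.8%

In a functional assay on BT-549 cells (Homo sapiens) for inhibition, read by sulforhodamine B assay, with a stated time of 48 h, tested at 10 uM (a lower number here means less inhibition, a higher number more inhibition at the concentration tested (going by the name of the read-out)), compound 1 gives 20.3%, while compound 2 gives 23.8%. For the measured compounds named here, the only measured step between them is a number 3.5 percentage points higher from compound 1 to compound 2 (within the scatter). Compound 2 therefore stands at the top of these two numbers, but the scatter of this kind of measurement is wide enough that the two compounds cannot be told apart.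

Compound 3 `Fc1ccccc1-c1cn2ccnc2c(-c2ccc3ncn(C4CCCCC4)c3c2)n1` has not yet been measured. It differs from compound 2 in one place: 2-fluorophenyl in place of 4-chlorophenyl on an aromatic carbon. Going by the values given here, the single measured step, from one halogen on the phenyl ring to another, is the only guide, and it was within the scatter. The new change is of a related kind, exchanging one halogen-bearing phenyl for another, so the expectation in this assay is a step that stays within the scatter, without a clear direction. The step of a number 2.8 percentage points lower from compound 2 to compound 3 (within the scatter) is the estimated size of that change. For compound 3 the estimate is 21%, with a range from 6% to 38%.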

Compound 3, a percentage reported as inhibition, at one concentration (the size of the read-out at that concentration, not a potency): 4.08%
Compound 3: middle estimate off by 16.9 percentage points, on the high side, outside the stated range (below it).
By their numbers in this assay, from the lowest: compound 3; then compounds 1 and 2 (each within the scatter of the next).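

Swapping one halogen for the other at the 4-position of the phenyl ring had changed little, but moving the fluorine gives a number 16.2 percentage points lower from compound 1 to compound 3 (beyond the scatter) in this assay, even though the halogen itself stays the same. Replacing 4-chlorophenyl with 2-fluorophenyl likewise gives a number 19.7 percentage points lower from compound 2 to compound 3 (beyond the scatter), so among these three compounds, where the halogen sits on this phenyl ring matters more than whether it is fluorine or chlorine. Nothing measured here explains why the inhibition falls.

From the compounds shown here alone, what remains open is whether the loss comes from having any group at this position of the phenyl ring or is particular to fluorine, which 2-chlorophenyl, 2-methylphenyl or 2-methoxyphenyl would help to separate. Going by these compounds, it is equally open how 3-fluorophenyl would behave, or whether an amine or a carboxylic acid on the phenyl ring would restore inhibition, and since each number comes from a single concentration, none of them gives a potency.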